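Adding a Hydroxy Group to an Inactive Benzamide Series

This account rests on a few compounds, and the source may have more. Where it says the series, first, only, none or still open, it means among the compounds named here.

Compound 2 `O=C(Nc1ccc(Sc2nc3ccccc3s2)cc1)c1cccc(Br)c1` carries the shared core of the series with a 3-bromophenyl amide. In an assay on isolated protein for inhibition of thiosulfate sulfurtransferase (Homo sapiens), with a stated time of 60 min, in the absence of a further agent (on this read-out lower numbers stand for stronger inhibition and higher numbers for weaker inhibition), compound 2 gives only the limit > 100000 nM, so no number is known for it. Compound 1 `O=C(Nc1ccc(Sc2nc3ccccc3s2)c(Cl)c1)c1cccc(Br)c1` differs from it by a chloro group on an aromatic carbon; in this assay compound 1 also gives the limit > 100000 nM. The step that the two limits leave unreadable from compound 1 to compound 2 spans two limits and cannot be read. Compound 3 `O=C(Nc1ccccc1)c1cc(Br)cc(Br)c1`, a smaller amide bearing bromo groups, gives the limit > 100000 nM in this assay as well. Thus the limit of > 100000 nM in this assay, at which 3 of the 3 values shown sit, describes everything measured so far: all three values sit at the limit, and compound 2 stands nowhere distinguishable among them.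

Compound 4 `O=C(Nc1ccc(Sc2nc3ccccc3s2)cc1)c1cccc(Br)c1O` is the next compound. (hydroxy in place of hydrogen on an aromatic carbon). Going by the values given here, no measured step bears on this change; the one step available, from compound 1 to compound 2, is unreadable. Since the limit of > 100000 nM in this assay, at which 3 of the 3 values shown sit, covers every value, there is no ground to expect a number in this assay for compound 4, and the expected step that the limit leaves unreadable from compound 2 to compound 4 is nothing beyond the scatter. Compound 4 is accordingly estimated at 150000 nM, within a range of 30000 nM to 1000000 nM, and is expected most likely to be reported only as a limit.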

Compound 4, half-maximal inhibitory concentration: > 100000 nM
Compound 4: no number, only a limit; the forecaster's own chance of this, stated with the estimate: 75%; the middle value is on the limit's open side.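

Compound 4 gives only a limit, as compound 2 does, and no step between the two can be read; one limit now describes every compound shown in this assay: the limit of > 100000 nM in this assay, at which 4 of the 4 values shown sit.

The compounds shown leave open what the hydroxy group does to inhibition, and which change to the shared core, if any, would yield a number in this assay.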